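Trifluoromethylphenyl for Methylphenyl on a Shared Acid Core

The source may report more compounds than this note shows. Statements on the series, on what has been measured and on what is new or still open speak of the compounds shown alone.

Measured compounds:
- compound 1, `O=C(O)CC1COc2cc(OCc3nc(-c4ccccc4)cs3)ccc21`: 0.16%
- compound 2, `Cc1ccccc1-c1nc(C)c(COc2ccc3c(c2)OCC3CC(=O)O)s1`: 10.7%

In a functional assay on CHO cells for agonist activity at Free fatty acid receptor 1 (Homo sapiens), read by FLIPR and calcium flux, tested at 100 nM (on this read-out higher numbers stand for a stronger effect at the one concentration tested and lower numbers for a weaker effect), compound 2 gives 10.7%, the higher of the two numbers available. Compound 1 gives 0.16%, a gap beyond the usual scatter. Compound 3, `Cc1nc(-c2cccc(C(F)(F)F)c2)sc1COc1ccc2c(c1)OCC2CC(=O)O`, differs from compound 2 by 3-(trifluoromethyl)phenyl in place of 2-methylphenyl on an aromatic carbon. Going by the values given here, no measured pair shows what this kind of change does on this core, so the expected step is small and without a clear direction, a number 1.3 percentage points higher from compound 2 to compound 3 (within the scatter), staying within the scatter. On that basis compound 3 is estimated at 12%, with a range from 2% to 30%.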

Compound 3, a percentage reported as activity, at one concentration (the size of the read-out at that concentration, not a potency): 35.7%
Compound 3: middle estimate off by 23.7 percentage points, on the low side, and the stated range ends below it.
By their numbers in this assay, from the lowest: compound 1; then compound 2; then compound 3.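

In this assay, putting 3-(trifluoromethyl)phenyl in place of 2-methylphenyl on the aromatic carbon next to the ring nitrogen and the ring sulfur gives a number 25 percentage points higher from compound 2 to compound 3 (beyond the scatter). Going by these compounds alone, this is the first measured sign that the read-out on this shared core responds to a change in the group at this position. No measurement at hand explains the step. The swap alters both the substituent and its place on the phenyl ring, so the compounds shown leave open which of the two matters; 3-methylphenyl or 2-(trifluoromethyl)phenyl at this position would separate them.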